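Swapping the remaining benzyl for an ester

The source may hold more compounds than are shown below. What is called first, only, known or untested is meant among the compounds shown, and "the series" means these compounds.

Compound 1 `O=C(NCc1cn(Cc2ccccc2)nn1)c1cn(Cc2ccccc2)nn1` carries two benzyl groups, and in a functional assay on B16 cells (Mus musculus) for cytotoxicity, read by MTT assay, with a stated time of 48 h (a higher number here means a weaker inhibitor, a lower number a stronger inhibitor), compound 1 gives 300 nM. Compound 2 `CCOC(=O)Cn1cc(CNC(=O)c2cn(Cc3ccccc3)nn2)nn1` differs from it in one place, (ethoxycarbonyl in place of phenyl on a saturated chain carbon bound to an aromatic nitrogen), and in this assay compound 2 gives 35000 nM; that step is a 120-fold higher number from compound 1 to compound 2 (2.07 log units; beyond the scatter). Compound 3 `CCOC(=O)Cn1cc(C(=O)Nc2cccc(-c3cn(Cc4ccccc4)nn3)c2)nn1` rests on a different core, and how its core differs from that of compound 1 is not broken down here; in this assay compound 3 gives 20400 nM. Compound 4 `CCOC(=O)Cn1cc(C(=O)Nc2cccc(-c3cn(CC(=O)OCC)nn3)c2)nn1` has not been measured and differs from compound 3 by the same change, (ethoxycarbonyl in place of phenyl on a saturated chain carbon bound to an aromatic nitrogen), at the same place. Because the earlier instance gave a 120-fold higher number from compound 1 to compound 2 (2.07 log units; beyond the scatter), a weakening step is expected again, though compound 3 already sits high and the assay may report only a limit. The expected step is a 3.9-fold higher number from compound 3 to compound 4 (0.59 log units; beyond the scatter). Compound 4 is therefore expected to give about 80000 nM.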

Compound 4, half-maximal inhibitory concentration: > 100000 nM
Compound 4: only a limit was reported (the forecaster's own chance of this, stated with the estimate: 35%); at least 1.2-fold (0.09 log units) between middle value and limit.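

Carrying the change to the other core gives an at least 4.9-fold higher number from compound 3 to compound 4 (0.69 log units; beyond the scatter) in this assay, so the number moves the same way on both cores shown. For compound 4, the reading of > 100000 nM is a limit of the assay and not a number. The direction of the change therefore carries over between these two cores, but whether its size does remains unsettled: the same change on two cores in this assay, a 120-fold higher number (2.07 log units; beyond the scatter) from compound 1 to compound 2 and an at least 4.9-fold higher number (0.69 log units; beyond the scatter) from compound 3 to compound 4; the limit leaves it open whether they differ.

The compounds shown leave open what compound 4 would give without a limit. They also leave open how either core would respond to a carboxylic acid or an amine in place of the ethoxycarbonyl on a saturated chain carbon bound to an aromatic nitrogen.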